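This account rests on a few compounds, and the source may have more. Where it says the series, first, only, none or still open, it means among the compounds named here.

Series notes. Compound 1 `Nc1sc(-c2ccccc2)c(-c2ccc(Cl)cc2)c1C(=O)N1CCCC1` is the reference point; in a functional assay on A549 cells (Homo sapiens) for cytotoxicity, read by sulforhodamine B assay, with a stated time of 72 h (on this read-out lower numbers stand for stronger inhibition and higher numbers for weaker inhibition), compound 1 gives 5800 nM. Compound 2 `Nc1sc(-c2ccccc2)c(-c2ccc(Cl)cc2)c1C(=O)NCc1ccccc1` carries the change benzylamino in place of pyrrolidin-1-yl on a carbonyl carbon and in this assay compound 2 gives 8510 nM, a step of a 1.5-fold higher number from compound 1 to compound 2 (0.17 log units; within the scatter). Compound 3 `Nc1sc(-c2ccc(Br)cc2)c(-c2ccc(Cl)cc2)c1C(=O)N1CCCC1` differs from compound 1 by bromo in place of hydrogen on an aromatic carbon; in this assay compound 3 gives 7460 nM, a step of a 1.3-fold higher number from compound 1 to compound 3 (0.11 log units; within the scatter). Compound 4 `Nc1sc(-c2ccc(Br)cc2)c(-c2ccc(Cl)cc2)c1C(=O)NCc1ccccc1` is not yet measured. It differs from compound 3 by benzylamino in place of pyrrolidin-1-yl on a carbonyl carbon, the same change that takes compound 1 to compound 2, both at a place described in the same words; it appears twice in the set. Among the compounds with values here, for compound 4 the step is expected to be about a 1.4-fold higher number from compound 3 to compound 4 (0.15 log units; within the scatter), resting on the only precedent, because from compound 1 to compound 2 the step was a 1.5-fold higher number from compound 1 to compound 2 (0.17 log units; within the scatter). Compound 4 is therefore estimated at 10500 nM, with 5000 nM to 22000 nM as the plausible range.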

Compound 4, half-maximal inhibitory concentration: 18700 nM
For compound 4 the middle estimate is 1.8-fold (0.25 log units) below the measured one, within the range that was stated.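

In this assay, benzylamino in place of pyrrolidin-1-yl on the bromo-bearing core gives a 2.5-fold higher number from compound 3 to compound 4 (0.40 log units; beyond the scatter), and bromo in place of hydrogen on the benzylamino-bearing core gives a 2.2-fold higher number from compound 2 to compound 4 (0.34 log units; beyond the scatter). The amide change carries from one core to the other without a difference that can be told from the scatter: the same change on two cores in this assay, a 1.5-fold higher number (0.17 log units; within the scatter) from compound 1 to compound 2 and a 2.5-fold higher number (0.40 log units; beyond the scatter) from compound 3 to compound 4, 1.7-fold (0.23 log units) apart, within the scatter of two such steps With only one pair of cores for each change, this neither establishes a larger step on the second core nor gives a rule for other cores, and the bromo change reads the same way: the same change on two cores in this assay, a 1.3-fold higher number (0.11 log units; within the scatter) from compound 1 to compound 3 and a 2.2-fold higher number (0.34 log units; beyond the scatter) from compound 2 to compound 4, 1.7-fold (0.23 log units) apart, within the scatter of two such steps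

Going by these compounds, whether this holds for other groups on the carbonyl carbon, such as morpholin-4-yl or a methylamino group, remains open. So does the outcome with fluoro or methoxy in place of bromo.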